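This account rests on a few compounds, and the source may have more. Where it says the series, first, only, none or still open, it means among the compounds named here.

Measured so far:
- compound 1, `FC(F)(F)c1ccc(COc2cccc(Nc3ncnc4cc5c(cc34)OCCOCCOCCO5)c2)cc1`: 2760 nM
- compound 2, `c1ccc(COc2cccc(Nc3ncnc4cc5c(cc34)OCCOCCOCCO5)c2)cc1`: > 100000 nM

In a functional assay on DU-145 cells (Homo sapiens) for antiproliferative activity, read by MTT assay, with a stated time of 72 h (on this read-out higher numbers stand for weaker inhibition and lower numbers for stronger inhibition), compound 1 gives 2760 nM. For compound 2 the same read-out reports only a limit, > 100000 nM, so compound 2 sits at the weak end of what is shown, on the limit itself (the limit of > 100000 nM in this assay, at which 1 of the 2 values shown sits). For the measured compounds named here, the single measured step, an at least 36-fold higher number from compound 1 to compound 2 (1.55 log units; beyond the scatter), is large and beyond the scatter: taking away the trifluoromethyl on the aromatic carbon of compound 1 leaves compound 2 without a measurable number.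

Compound 3, `O=[N+]([O-])c1ccc(COc2cccc(Nc3ncnc4cc5c(cc34)OCCOCCOCCO5)c2)cc1`, comes from compound 2 by nitro in place of hydrogen on an aromatic carbon of the six-membered carbon-only ring, para to a large group. Going by the values given here, the only step that bears on it is the one from compound 1 to compound 2, which shows that a substituent at that position matters greatly. A substituent is restored here, though a different one, so a move back toward measurable inhibition is expected, of uncertain size given that compound 2 is a limit. For compound 3 the expected value in this assay is 12000 nM, within 2500 nM to 100000 nM, an expected step of an at least 8.3-fold lower number from compound 2 to compound 3 (0.92 log units; beyond the scatter).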

Compound 3, half-maximal inhibitory concentration: > 100000 nM
Compound 3 ended at the assay's limit; the forecaster's own chance of this, stated with the estimate: 30%; at least 8.3-fold (0.92 log units) between middle value and limit.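

In this assay, nitro in place of trifluoromethyl on the aromatic carbon gives an at least 36-fold higher number from compound 1 to compound 3 (1.55 log units; beyond the scatter), so the 4-nitrobenzyl group does not recover what the 4-trifluoromethylbenzyl group gives. Restoring a substituent at this place, para to a large group, is therefore not enough in itself, and of the three groups shown there, only trifluoromethyl gives a measurable number. Compound 2 and compound 3 each report only a limit, so the step from hydrogen to nitro cannot be read, and the series now gathers at the weak end: the limit of > 100000 nM in this assay, at which 2 of the 3 values shown sit.

On these data alone, it remains open whether another group at this place, such as an amine, a carboxylic acid, a methoxy group or a longer chain, would give a measurable number, or whether trifluoromethyl stands alone among substituents here. Also open, as far as these compounds go, is whether trifluoromethyl would keep its measurable number on another carbon of the same ring, and how compound 2 and compound 3 would compare if either gave a number rather than a limit.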